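From hydroxy to amino on a small side chain

The source may hold more compounds than are shown below. What is called first, only, known or untested is meant among the compounds shown, and "the series" means these compounds.

Results so far in a functional assay on A2780 cells (Homo sapiens) for antiproliferative activity, read by MTT assay, with a stated time of 48 h (on this read-out higher numbers stand for weaker inhibition and lower numbers for stronger inhibition), are these
Compound 1 `COc1ccc(C(=O)c2ccc(OC)c3c2C=CC(C)(C)O3)c(NC(=O)CN)c1` gives 890 nM
Compound 2 `C=C(c1cc(OC)c(OC)c(OC)c1)c1ccc(OC)cc1NC(=O)CO` gives 30 nM

Compound 2 has the lower number of the pair, which makes it the stronger inhibitor here, and its gap to compound 1 lies beyond the scatter of repeat measurements. Compound 3 `C=C(c1cc(OC)c(OC)c(OC)c1)c1ccc(OC)cc1NC(=O)CN` keeps the core of compound 2 and changes one place, a saturated chain carbon bound to a carbonyl carbon, where amino stands in place of hydroxy amino in place of hydroxy on a saturated chain carbon bound to a carbonyl carbon and the rest stays the same. Within the data shown here, compound 1 also carries ((aminomethyl)carbonyl)amino, but on a different core, so no measured pair shows this swap alone. In this assay the expected move is slight, toward a higher number and within the scatter, an estimated 1.7-fold higher number from compound 2 to compound 3 (0.22 log units; within the scatter) in size. For compound 3 an estimate of 50 nM is expected, with 12 nM and 250 nM as the likely ends of the range.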

Compound 3, half-maximal inhibitory concentration: 30 nM
For compound 3 the middle estimate is 1.7-fold (0.22 log units) above the measured one; measured number inside the range.
By their numbers in this assay, from the lowest: compounds 2 and 3 (each within the scatter of the next); then compound 1.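

In this assay the swap of hydroxy for amino on a saturated chain carbon bound to a carbonyl carbon gives no change at the digits printed from compound 2 to compound 3 (within the scatter) on the shared core, so at this position the read-out does not tell the two groups apart. Among these compounds, this is the first pair that shows the swap alone, whereas compound 1 carries ((aminomethyl)carbonyl)amino on a different core and so could not show what that group does by itself. Nothing measured here explains why the two groups read alike.

Going by these compounds, whether a dimethylamino group, a carboxylic acid or a longer chain at this place would read the same remains open. The core of compound 1 has no hydroxy partner among the compounds shown, so it is also open whether the swap would behave the same way there.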